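The source may report more compounds than this note shows. Statements on the series, on what has been measured and on what is new or still open speak of the compounds shown alone.

Compounds measured in an assay on CHO cells for displacement of a labelled ligand from prostacyclin receptor (Homo sapiens); a lower number here means a stronger inhibitor, a higher number a weaker inhibitor:
compound 1 `CCCC[C@H](C)C[C@H](O)/C=C/[C@H]1[C@H](O)CC(=O)[C@@H]1SCCCCCC(=O)O` gives 3.3 nM;
compound 2 `COCc1cccc(C[C@H](O)/C=C/[C@H]2[C@H](O)CC(=O)[C@@H]2SCCCSCC(=O)O)c1` gives > 10000 nM, which is a limit of the assay;
compound 3 `CCOCc1cccc(C[C@H](O)/C=C/[C@H]2[C@H](O)CC(=O)[C@@H]2SCCCSCC(=O)O)c1` gives > 10000 nM, again a limit of the assay.

Compound 3 therefore stands at the limit of the assay, with no number of its own. Going by the values given here, compound 2 sits at the same limit, so the step from compound 2 to compound 3 is a step that the two limits leave unreadable from compound 2 to compound 3; the only change there is methyl in place of hydrogen on a saturated chain carbon bound to an oxygen on a saturated carbon. Among the compounds with values here, the single numbered value belongs to compound 1, whose chain carries no aromatic ring. Two of the three values shown sit at the limit of > 10000 nM in this assay, at which 2 of the 3 values shown sit.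

Compound 4 `COc1ccccc1C[C@H](O)/C=C/[C@H]1[C@H](O)CC(=O)[C@@H]1SCCCSCC(=O)O` differs from compound 3 by 2-methoxyphenyl in place of 3-(ethoxymethyl)phenyl on a saturated chain carbon, two bonds along the chain from a double-bonded chain carbon and an oxygen on a saturated carbon. Within the data shown here, no measured step tells how the ring substituent and its position affect binding: the one step that exists, from compound 2 to compound 3, is unreadable, and compound 1 shares only the core. With both aromatic compounds at the limit, compound 4 is expected to stay weak, so the step from compound 3 to compound 4 is estimated as a number no higher from compound 3 to compound 4 (the limit leaves the size open). The inhibition constant of compound 4 is thus estimated at 10000 nM, in a range from 1500 nM to 50000 nM, with a fair chance that only a limit is reported again.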

Compound 4, inhibition constant: > 10000 nM
Compound 4: a limit, no number (the forecaster's own chance of this, stated with the estimate: 60%); the middle value sits exactly at the limit.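

Going by these compounds alone, no step among compound 2, compound 3 and compound 4 can be read, as all three give only a limit of the assay in this assay: the limit of > 10000 nM in this assay, at which 3 of the 4 values shown sit. The compounds shown leave open whether changing the substituent on the aromatic ring, or its position, shifts the inhibition constant at all.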